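The source may hold more compounds than are shown below. What is called first, only, known or untested is meant among the compounds shown, and "the series" means these compounds.

In an ADME assay on HEK-293T cells (Homo sapiens) for cytotoxicity, read by CCK-8 assay, with a stated time of 48 h (on this read-out higher numbers stand for weaker inhibition and lower numbers for stronger inhibition), compound 1 `O=S(=O)(NCCNC(=S)Nc1cccc(Cl)c1)c1ccc(-c2ccccc2OCc2cccc(O)c2)s1` gives 17400 nM as its value. Compound 2 `O=[N+]([O-])c1ccc(NC(=S)NCCNS(=O)(=O)c2ccc(-c3ccccc3OCc3cccc(O)c3)s2)cc1` gives > 20000 nM and that is a limit of the assay, not a number. Compound 3 `O=[N+]([O-])c1cccc(NC(=S)NCCNS(=O)(=O)c2ccc(-c3ccccc3OCc3cccc(O)c3)s2)c1` has 3-nitrophenyl in place of 4-nitrophenyl on an amide-type nitrogen, and 3-nitrophenyl in place of 4-nitrophenyl on an amide-type nitrogen is the whole difference from compound 2. Among the compounds with values here, the one measured step at that place, with 4-nitrophenyl in place of 3-chlorophenyl, is an at least 1.1-fold higher number from compound 1 to compound 2 (0.06 log units; that floor lies within the scatter) and shows no size beyond the scatter. A step beyond the scatter is therefore not expected in this assay, and the estimated step is a number no higher from compound 2 to compound 3 (the limit leaves the size open) at its middle. Compound 3 is expected at 20000 nM with 10000 nM and 40000 nM as the ends of the estimated range.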

Compound 3, half-maximal inhibitory concentration: 13800 nM
Estimate against measurement, compound 3: 1.4-fold (0.16 log units) above, and the stated range covers the measured number.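

In this assay, moving the nitro group gives an at least 1.4-fold lower number from compound 2 to compound 3 (0.16 log units; that floor lies within the scatter). That size is only a floor, as the value of compound 2 is a limit and not a number: the limit of > 20000 nM in this assay, at which 1 of the 3 values shown sits.

Within the data shown here, compound 3 gives the first exact number for a nitro compound here, so the change from chloro can now be sized: a 1.3-fold lower number from compound 1 to compound 3 (0.10 log units; within the scatter). Open, from the compounds shown here alone, is whether an aminophenyl group, a carboxyphenyl group or a longer alkyl chain on the amide-type nitrogen would shift the number beyond the scatter.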